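The source may report more compounds than this note shows. Statements on the series, on what has been measured and on what is new or still open speak of the compounds shown alone.

Measured in a physicochemical assay for lipophilicity; a higher number here means a more lipophilic compound, a lower number a more polar compound:
- Compound 1 `C=C(c1cccc2ccccc12)C1CCC2(CC1)COC(Nc1ccc(C)cc1)OO2`: 6.08
- Compound 2 `C=C(c1ccc2ccccc2c1)C1CCC2(CC1)COC(Nc1ccc(Cl)cc1)OO2`: 6.15

Compound 2 stands level with compound 1, the two values lying within the scatter of each other. Compound 3 `C=C(c1ccc2ccccc2c1)C1CCC2(CC1)COC(Nc1ccc(C)cc1)OO2` differs from compound 2 by one change: methyl in place of chloro on an aromatic carbon. Among the compounds with values here, no measured pair shows this change alone. No step beyond the scatter is expected in this assay, and any shift is expected to be slightly downward. Compound 1 also carries the (4-methylphenyl)amino group and gives 6.08, which points the same way. The expected step is a number 0.07 log units lower from compound 2 to compound 3 (within the scatter). The estimate for compound 3 is 6.08, with an expected range of 5.8 to 6.35.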

Compound 3, partition coefficient: 6.08
The estimate for compound 3 equals the measured number at the digits printed, and the stated range covers the measured number.
By their numbers in this assay, from the lowest: compounds 1, 3 and 2 (each within the scatter of the next).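

In this assay, methyl in place of chloro on an aromatic carbon can now be read alone, and 4-chlorophenyl to 4-methylphenyl gives a number 0.07 log units lower from compound 2 to compound 3 (within the scatter). Naphthalen-2-yl in place of naphthalen-1-yl on the double-bonded chain carbon gives no change at the digits printed from compound 1 to compound 3 (within the scatter), so neither single change separates its pair in this series. Nothing measured on these compounds accounts for either step.

On these data alone, whether a carboxylic acid or an amine on that aromatic carbon would give a step beyond the scatter remains open. As far as these compounds go, whether a longer chain there would do so also remains open.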